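Aryl ureas: a second fluoro on the aryl ring

The source may report more compounds than this note shows. Statements on the series, on what has been measured and on what is new or still open speak of the compounds shown alone.

Compound 1 `C[C@@H](NC(=O)Nc1ccccc1F)c1ccccc1` gives 97% in an ADME assay on the whole organism with Oryza sativa as the target, tested at 0.1 uM; on this read-out lower numbers stand for a stronger effect and higher numbers for a weaker effect at the one concentration tested. Its two neighbours are compound 2 `C[C@H](NC(=O)Nc1ccccc1F)c1ccccc1`, which gives 98% in this assay, and compound 3 `C[C@@H](NC(=O)Nc1ccccc1Br)c1ccccc1`, which gives 99%. Compound 1 thus carries the lowest of the three numbers shown, yet both neighbours sit within the scatter of it: a number 1 percentage points higher from compound 1 to compound 2 (within the scatter), a step that rests solely on (the fact that compounds 1 and 2 differ only in the configuration as drawn), and a number 2 percentage points higher from compound 1 to compound 3 (within the scatter). Going by the values given here, nothing among the measured compounds separates one from another beyond the scatter.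

Compound 4 `C[C@@H](NC(=O)Nc1cccc(F)c1F)c1ccccc1` is the next member. Relative to compound 1 the change is fluoro in place of hydrogen on an aromatic carbon. Among the compounds with values here, the only measured step that touches the same aromatic ring is the exchange of fluoro for bromo, and it stayed within the scatter; the configurational step between compound 1 and compound 2 did likewise. With all three measured numbers crowded near the top of the scale, a further fluoro on that ring is expected to leave the read-out where it stands, so the step of no change at the digits printed from compound 1 to compound 4 (within the scatter) is expected to fall within the scatter. For compound 4 the estimate in this assay is 97%, with a range from 90% to 100%.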

Compound 4, a percentage reported as activity, at one concentration (the size of the read-out at that concentration, not a potency): 100%
Estimate against measurement, compound 4: 3 percentage points below, within the range that was stated.
By their numbers in this assay, from the lowest: compounds 1, 2, 3 and 4 (each within the scatter of the next).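

In this assay, the added fluoro, on an aromatic carbon ortho to a fluoro group and meta to a large group, gives a number 3 percentage points higher from compound 1 to compound 4 (within the scatter). Going by these compounds alone, the earlier steps covered only an exchange of the halogen already on the ring and a difference in drawn configuration, so this is the first reading at a ring carbon that carries hydrogen in compound 1, and it adds a fluoro rather than replacing one; this step also leaves the series without any separation beyond the scatter. No information at hand accounts for this step or connects it with any property of the added fluoro.

Whether a methoxy group, an amine or a carboxylic acid on this same aromatic carbon would give a step beyond the scatter remains open, since fluoro is the only group shown there. Also open, on these data alone, is whether the drawn configuration counts for anything once this second fluoro is present, and whether any change to the shared core can give a number well away from the 100% of compound 4 in this assay.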